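The source may hold more compounds than are shown below. What is called first, only, known or untested is meant among the compounds shown, and "the series" means these compounds.

Compound 1, `Nc1cc(N)c2nc(-c3ccccc3)c(NCc3ccc(Cl)c(Cl)c3)nc2c1`, gives in a functional assay on NCI/ADR-RES cells (Homo sapiens) for inhibition, read by sulforhodamine B assay, with a stated time of 48 h (a higher number here means that more compound is tolerated, a lower number that less compound is tolerated), a value that is a limit of the assay, < 100000 nM.
Compound 2, `COc1ccc(CNc2nc3cc(N)cc(N)c3nc2-c2ccccc2)cc1OC`, gives in this assay a value that is also a limit, < 100000 nM.
Compound 3, `Nc1cc(N)c2nc(-c3ccccc3)c(NCc3ccc(F)cc3)nc2c1`, gives in this assay 28200 nM.

Compound 3 is therefore the only one of the three with a number; the other two sit at a limit, as the limit of < 100000 nM in this assay, at which 2 of the 3 values shown sit, states, so none of the three can be ranked against the others. The steps a step that the limit leaves unreadable from compound 1 to compound 3 and a step that the limit leaves unreadable from compound 2 to compound 3 are unreadable in size for the same reason, and the step that the two limits leave unreadable from compound 1 to compound 2 likewise.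

Compound 4, `COc1ccc(CNc2nc3cc(N)cc(N)c3nc2-c2ccccc2)cc1`, is not yet measured. It differs from compound 3 by methoxy in place of fluoro on an aromatic carbon. The only measured step that exchanges one group on this aromatic ring for another, from compound 2 to compound 3, cannot be read, so the shown data give no size for what this exchange does. With no readable step to lean on, the expectation is that compound 4 stays in the region of compound 3, with a step of a 1.1-fold higher number from compound 3 to compound 4 (0.03 log units; within the scatter) that is not expected to exceed the usual scatter in either direction. Compound 4 is thus estimated at 30000 nM, within a range from 8000 nM to 100000 nM.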

Compound 4, concentration lethal to 50% of the cells: < 100000 nM
Compound 4 was reported as a limit; the forecaster's own chance of this, stated with the estimate: 30%; the middle value is on the limit's open side.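

In this assay, within the data shown here, compound 4 also gives a limit, so its steps from compound 1, compound 2 and compound 3 cannot be read, and no new step emerges: the limit of < 100000 nM in this assay, at which 3 of the 4 values shown sit. The compounds shown leave open how far compound 1, compound 2 and compound 4 truly lie from compound 3, and whether methoxy in place of fluoro changes the value at all.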